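The source may report more compounds than this note shows. Statements on the series, on what has been measured and on what is new or still open speak of the compounds shown alone.

Of the compounds shown here, three built on one shared core have been measured in a functional assay on K562 cells (Homo sapiens) for antiproliferative activity, read by resazurin assay, with a stated time of 72 h; a lower number here means a stronger inhibitor of growth, a higher number a weaker inhibitor of growth. Compound 1 `CN(C)C1=NN(c2ccccc2)CN(c2ccccc2Cl)C1=O` gives 5.8 ug/mL. Compound 3 `O=C1C(N2CCCCC2)=NN(c2ccccc2)CN1c1ccccc1Cl` gives 42 ug/mL. For compound 2 `O=C1C(N2CCCCC2)=NN(c2ccc(Cl)cc2)CN1c1ccccc1Cl` the assay records only > 50 ug/mL, which is a limit of the assay (the limit of > 50 ug/mL in this assay, at which 1 of the 3 values shown sits). The two steps among these compounds differ in size. From compound 3 to compound 1 the change is dimethylamino in place of piperidin-1-yl on a carbon with a double bond to nitrogen, and a 7.2-fold lower number from compound 3 to compound 1 (0.86 log units; beyond the scatter). The cores of compounds 2 and 3 differ by chloro in place of hydrogen on an aromatic carbon, and an at least 1.1-fold lower number from compound 2 to compound 3 (0.07 log units; that floor lies within the scatter).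

Compound 4 `CN(C)C1=NN(c2ccc(Cl)cc2)CN(c2ccccc2Cl)C1=O` has not been measured. It differs from compound 2 by dimethylamino in place of piperidin-1-yl on a carbon with a double bond to nitrogen, the same kind of change as that from compound 3 to compound 1, though the surroundings differ: in compound 4 the place lies two ring bonds from the ring atom that bears a 4-chlorophenyl group, whereas in compound 1 it lies two ring bonds from the ring atom that bears a phenyl group. For compound 4 the expected step is an at least 5.5-fold lower number from compound 2 to compound 4 (0.74 log units; beyond the scatter), resting on the earlier step of a 7.2-fold lower number from compound 3 to compound 1 (0.86 log units; beyond the scatter). The starting point for compound 2 is only a limit, so the estimate is wide. Compound 4 is expected to give 9 ug/mL, between 4 ug/mL and 30 ug/mL.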

Compound 4, concentration for 50% growth inhibition: 11 ug/mL
Beside the measured number, compound 4's estimate is 1.2-fold (0.09 log units) below it; measured number inside the range.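

In this assay, dimethylamino in place of piperidin-1-yl carries over in direction to the core with the 4-chlorophenyl group, giving an at least 4.5-fold lower number from compound 2 to compound 4 (0.65 log units; beyond the scatter), and the step lies beyond the scatter on both cores: the same change on two cores in this assay, a 7.2-fold lower number (0.86 log units; beyond the scatter) from compound 3 to compound 1 and an at least 4.5-fold lower number (0.65 log units; beyond the scatter) from compound 2 to compound 4; the limit leaves it open whether they differ For compound 2, > 50 ug/mL is a limit of the assay and not a number, so the true size of the step on that core stays unknown and equal size on the two cores is not shown. Among the dimethylamino compounds, chloro in place of hydrogen gives a 1.9-fold higher number from compound 1 to compound 4 (0.28 log units; within the scatter), which is within the scatter, and the piperidin-1-yl pair gives no firmer reading of this change: the same change on two cores in this assay, an at least 1.1-fold lower number (0.07 log units; that floor lies within the scatter) from compound 2 to compound 3 and a 1.9-fold lower number (0.28 log units; within the scatter) from compound 4 to compound 1; the limit leaves it open whether they differ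

The compounds shown leave open whether other amines, such as pyrrolidin-1-yl, morpholin-4-yl or diethylamino, would behave like dimethylamino or like piperidin-1-yl. They also leave open whether the step would hold with a 4-methoxyphenyl group in place of the 4-chlorophenyl group.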